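Fluoro for chloro on the benzyl ring of dithiocarbamate triazoles

A few compounds are considered here, and "the series" means these few. Any claim that something is new, unique, unknown or untested is made for them only; others in the source may bear on it.

Measured compounds:
compound 1 `O=C(OCc1ccccc1)N1CCN(C(=S)SCc2cn(Cc3ccc(Cl)cc3)nn2)CC1`, 31300 nM
compound 2 `O=C(OCc1ccccc1)N1CCN(C(=S)SCc2cn(Cc3ccc(F)cc3)nn2)CC1`, 17600 nM
compound 3 `S=C(SCc1cn(Cc2ccccc2Cl)nn1)N1CCNCC1`, 45200 nM

In a functional assay on MGC-803 cells (Homo sapiens) for inhibition, read by MTT assay, with a stated time of 72 h (a higher number here means a weaker inhibitor, a lower number a stronger inhibitor), compound 1 gives 31300 nM and compound 2 gives 17600 nM; the change between them is fluoro in place of chloro on an aromatic carbon, and the step is a 1.8-fold lower number from compound 1 to compound 2 (0.25 log units; within the scatter). Compound 3 gives 45200 nM; the difference between its core and that of compound 1 is not broken down here. Compound 4 `Fc1ccccc1Cn1cc(CSC(=S)N2CCNCC2)nn1` is not yet measured. It differs from compound 3 by fluoro in place of chloro on an aromatic carbon, the same kind of change as from compound 1 to compound 2, though the place differs: ortho to a large group in compound 4, para to a large group in compound 2. Because a 1.8-fold lower number from compound 1 to compound 2 (0.25 log units; within the scatter) is small, a similarly small step is expected in this assay, a 1.5-fold lower number from compound 3 to compound 4 (0.18 log units; within the scatter). For compound 4 the estimate is 30000 nM, between 12000 nM and 80000 nM.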

Compound 4, half-maximal inhibitory concentration: 19400 nM
Compound 4: middle estimate off by 1.5-fold (0.19 log units), on the high side; the measured number falls inside the stated range.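

In this assay, fluoro in place of chloro gives a 2.3-fold lower number from compound 3 to compound 4 (0.37 log units; beyond the scatter), and the two cores can be set side by side without their steps being told apart: the same change on two cores in this assay, a 1.8-fold lower number (0.25 log units; within the scatter) from compound 1 to compound 2 and a 2.3-fold lower number (0.37 log units; beyond the scatter) from compound 3 to compound 4, 1.3-fold (0.12 log units) apart, within the scatter of two such steps. On these two cores, then, the change carries over with no measurable difference in the size of its step. For the compounds shown here, this does not show that it will lower the number on any other core, since only the step on the core of compound 3 lies beyond the scatter, and the two steps differ in the place of the change as well as in the core.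

The compounds shown leave open how a bromo or a methoxy group in place of the halogen would read in this assay. They also leave open whether the step would hold with an amide or a longer chain on the core.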